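Swapping methoxy for (methylsulfonyl)methyl on the side chain

A few compounds are considered here, and "the series" means these few. Any claim that something is new, unique, unknown or untested is made for them only; others in the source may bear on it.

- Compound 1 `CCOc1cc(C)c(-c2cccc(CNc3ccc(OCC(=O)O)c(F)c3)c2)c(C)c1`: 3.04
- Compound 2 `CCCOc1cc(C)c(-c2cccc(CNc3ccc(OCC(=O)O)c(F)c3)c2)c(C)c1`: 3.59
- Compound 3 `COCCOc1cc(C)c(-c2cccc(CNc3ccc(OCC(=O)O)c(F)c3)c2)c(C)c1`: 2.47

In a physicochemical assay for lipophilicity, read by HPLC, in phosphate buffer, measured as octanol-water partition, at pH 7.4, tested at 100 uM (a higher number here means a more lipophilic compound, a lower number a more polar compound), compound 3 stands lowest of the three at 2.47. Compound 4 `Cc1cc(OCCCS(C)(=O)=O)cc(C)c1-c1cccc(CNc2ccc(OCC(=O)O)c(F)c2)c1` differs from it in one place: (methylsulfonyl)methyl in place of methoxy on a saturated chain carbon, two bonds along the chain from an oxygen on an aromatic ring. The change lies on a saturated chain carbon, two bonds along the chain from an oxygen on an aromatic ring. Earlier changes at this place give some guidance. Methyl entering gave a number 0.55 log units higher from compound 1 to compound 2 (beyond the scatter), while methoxy entering gave a number 0.57 log units lower from compound 1 to compound 3 (beyond the scatter). Exchanging those two groups gave a number 1.12 log units lower from compound 2 to compound 3 (beyond the scatter). Going by the values given here, no measured compound carries (methylsulfonyl)methyl, so these steps guide only loosely. The expected change in this assay is a modest fall, a number 0.37 log units lower from compound 3 to compound 4 (beyond the scatter). For compound 4 the estimated value is 2.1, within an expected range of 1.6 to 2.6.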

Compound 4, distribution coefficient: 1.73
The estimate for compound 4 lay 0.37 log units above the measured number, and the stated range covers the measured number.
By their numbers in this assay, from the lowest: compound 4; then compound 3; then compound 1; then compound 2.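

In this assay the 3-(methylsulfonyl)propoxy group puts compound 4 lowest of the four, giving a number 0.74 log units lower from compound 3 to compound 4 (beyond the scatter) and a number 1.31 log units lower from compound 1 to compound 4 (beyond the scatter) and also a number 1.86 log units lower from compound 2 to compound 4 (beyond the scatter) as its steps. Adding heavy atoms at this place therefore does not by itself raise the number: methyl entering raised it in compound 2, whereas (methylsulfonyl)methyl takes it below even the methoxy of compound 3. Nothing measured here explains the size of these steps. From the compounds shown here alone, whether an amine or a carboxylic acid at this place would lower the number further stays open, as does the effect of a longer chain carrying the methylsulfonyl group.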